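Swapping the aryl group on the carbonyl carbon

The source may report more compounds than this note shows. Statements on the series, on what has been measured and on what is new or still open speak of the compounds shown alone.

Compound 3 `COc1ccc(C(=O)/C=C/c2cc(-c3cc(OC)c(OC)c(OC)c3)n[nH]2)cc1` stands highest of the two numbers obtained in a functional assay on SK-MEL-28 cells (Homo sapiens) for inhibition, read by sulforhodamine B assay, with a stated time of 48 h; a higher number here means that more compound is tolerated, a lower number that less compound is tolerated: in this assay compound 3 gives 9230 nM. Its nearest neighbour is compound 2 `COc1ccc(C(=O)/C=C/c2cc(-c3cc(OC)c(OC)c(OC)c3)n[nH]2)cc1OC`, which in this assay gives 6250 nM; the step of a 1.5-fold higher number from compound 2 to compound 3 (0.17 log units; within the scatter) stays within the scatter. Compound 1 `COc1cc(-c2cc(/C=C/C(=O)c3ccc(Cl)c(Cl)c3)[nH]n2)cc(OC)c1OC` reaches only the limit of this assay, > 100000 nM; this is a limit, not a number (the limit of > 100000 nM in this assay, at which 1 of the 3 values shown sits).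

Compound 4 `COc1cc(-c2cc(/C=C/C(=O)c3ccc(F)c(F)c3)[nH]n2)cc(OC)c1OC` differs from compound 3 by 3,4-difluorophenyl in place of 4-methoxyphenyl on a carbonyl carbon. Among the compounds with values here, two measured steps bear on this change, both at the same carbonyl carbon and both running from a ring with two halogens to a ring with methoxy: an at least 10-fold lower number from compound 1 to compound 3 (1.03 log units; beyond the scatter) and an at least 16-fold lower number from compound 1 to compound 2 (1.20 log units; beyond the scatter). Compound 4 runs the other way, back to a ring carrying two halogens, so a step of comparable size in the opposite direction is expected in this assay, that is a higher number, possibly reaching the limit again. The expected step is a 5.4-fold higher number from compound 3 to compound 4 (0.73 log units; beyond the scatter). Compound 4 is estimated to give about 50000 nM in this assay, with a range from 12000 nM to 150000 nM.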

Compound 4, concentration lethal to 50% of the cells: > 100000 nM
Compound 4 gave a limit, no number; the forecaster's own chance of this, stated with the estimate: 40%; middle value at least 2.0-fold (0.30 log units) from the limit.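

In this assay, 3,4-difluorophenyl on the carbonyl carbon gives an at least 10-fold higher number from compound 3 to compound 4 (1.03 log units; beyond the scatter) when it replaces 4-methoxyphenyl, and an at least 16-fold higher number from compound 2 to compound 4 (1.20 log units; beyond the scatter) when it replaces 3,4-dimethoxyphenyl. The gap between the methoxy-bearing rings and the rings with two halogens at this position is therefore not confined to 3,4-dichlorophenyl, and compound 1 and compound 4 both end at a limit rather than a number: the limit of > 100000 nM in this assay, at which 2 of the 4 values shown sit. The step between these two compounds cannot be read, so 3,4-difluorophenyl and 3,4-dichlorophenyl cannot be placed in any order here.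

The four compounds leave open whether a ring with a single halogen, such as 4-fluorophenyl, would stay at the limit or fall nearer to the methoxy-bearing compounds, and whether a ring carrying an amine or a hydroxy group would give a number lower than those of compound 2 and compound 3. They also leave open how far this pattern holds once the rest of the shared core is changed, since the carbonyl-bound ring is the only part that varies among them.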